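Cytotoxicity in Raji cells: indolyl variant of the biaryl amide

The source may report more compounds than this note shows. Statements on the series, on what has been measured and on what is new or still open speak of the compounds shown alone.

Compound 1 `CCOC(=O)CCCCCOc1cccc(CN(C(=O)c2ccc(-c3cccc(-c4ccccc4)c3)cc2)C(C)C)c1` and compound 2 `CCOC(=O)CCCCCOc1cccc(CN(C(=O)c2ccc(-c3cccc(OCC)c3)cc2)C(C)C)c1` share one core and differ at a single aromatic carbon, where compound 2 carries ethoxy in place of phenyl. In an ADME assay on Raji cells (Homo sapiens) for cytotoxicity, read by CellTiter-Glo and resazurin assay, with a stated time of 72 h (on this read-out higher numbers stand for an effect only at larger amounts of compound and lower numbers for an effect already at smaller amounts), compound 1 gives only a limit, > 26000 nM. In this assay compound 2 likewise gives only a limit, > 22300 nM. The step that the two limits leave unreadable from compound 1 to compound 2 has no readable size; both of its ends are limits, the limit of > 26000 nM in this assay, at which 1 of the 2 values shown sits, and (the limit of > 22300 nM in this assay, at which 1 of the 2 values shown sits). Compound 2 thus stands at one of the two limits seen in the series, with no numerical value to anchor it.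

Compound 3 `CCOC(=O)CCCCCOc1cccc(CN(C(=O)c2ccc(-c3ccc4cc[nH]c4c3)cc2)C(C)C)c1` differs from compound 2 by 1H-indol-6-yl in place of 3-ethoxyphenyl on an aromatic carbon. Among the compounds with values here, the only measured step, a step that the two limits leave unreadable from compound 1 to compound 2, involves the group on the same aromatic carbon but has no readable size; it shows only that exchanging one group there left both compounds at a limit. No direction or size of step can be drawn from it. The expected outcome for compound 3 is therefore another limit, with the step that the limit leaves unreadable from compound 2 to compound 3 expected to be small or unreadable. Compound 3 is estimated at 25000 nM, with a range from 8000 nM to 80000 nM.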

Compound 3, half-maximal effective concentration: > 26000 nM
Compound 3 ended at the assay's limit; the forecaster's own chance of this, stated with the estimate: 80%; middle value at least 1.0-fold (0.01 log units) away from the limit.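

In this assay compound 3 gives only a limit, > 26000 nM; the steps to it from compound 1 and from compound 2 cannot be read. The compounds shown leave open how far compound 1, compound 2 and compound 3 lie from their limits, and whether exchanging the group on this aromatic carbon changes cytotoxicity at all.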